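The source may hold more compounds than are shown below. What is called first, only, known or untested is meant among the compounds shown, and "the series" means these compounds.

In an ADME assay on SK-OV-3 cells (Homo sapiens) for cytotoxicity, read by sulforhodamine B assay, with a stated time of 48 h, tested at 10 uM (a lower number here means less inhibition, a higher number more inhibition at the concentration tested (going by the name of the read-out)), compound 2 `COc1nc2ccc(Br)cc2cc1C(c1ccccc1)n1cc(-c2ccc(F)cc2)nn1` gives 14.3%, while compound 1 `CCCCCCCc1cn(C(c2ccccc2)c2cc3cc(Br)ccc3nc2OC)nn1` gives 10.5%; the two numbers sit within the scatter of each other, and the step of a number 3.8 percentage points higher from compound 1 to compound 2 (within the scatter) confirms that. Compound 3 `COc1nc2ccc(Br)cc2cc1C(c1ccccc1)n1cc(CCCCCO)nn1` differs from compound 2 by 5-hydroxypentyl in place of 4-fluorophenyl on an aromatic carbon. Within the data shown here, only one measured step touches the same aromatic carbon, the one that put 4-fluorophenyl in place of heptyl, and it stayed within the scatter. Exchanging 4-fluorophenyl for 5-hydroxypentyl is therefore expected to give no step beyond the scatter, a number 2.3 percentage points lower from compound 2 to compound 3 (within the scatter). Compound 3 is estimated at 12%, with a range from 4% to 22%.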

Compound 3, a percentage reported as inhibition, at one concentration (the size of the read-out at that concentration, not a potency): 8.69%
Compound 3: the middle estimate sits 3.3 percentage points above what was measured; the measured number falls inside the stated range.
By their numbers in this assay, from the lowest: compounds 3, 1 and 2 (each within the scatter of the next).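

In this assay, a chain carrying hydroxy now stands on this aromatic carbon, and replacing the 4-fluorophenyl ring with it gives a number 5.6 percentage points lower from compound 2 to compound 3 (within the scatter) and stays close to the heptyl result. Within the chain alone, hydroxy in place of ethyl gives a number 1.8 percentage points lower from compound 1 to compound 3 (within the scatter) as the step. Thus, neither the exchange of ring for chain nor this hydroxy separates compounds 1, 2 and 3 here. Going by these compounds, whether an amine or a carboxylic acid at this carbon would give a step beyond the scatter stays open. Nothing available explains why these three numbers lie so close.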